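Aryl Swap on the Benzylamine Arm of a Bcl-2 Inhibitor

The source may hold more compounds than are shown below. What is called first, only, known or untested is meant among the compounds shown, and "the series" means these compounds.

Compound 1 `Cc1cc(Oc2ccc(Cn3nc4ccc(Cl)cc4c3C(=O)NS(=O)(=O)c3ccc(Cl)cc3)cc2)cc(C)c1Cl`: 510 nM
Compound 2 `Cc1cc(Oc2ccc(Cn3nc4ccc(Cl)cc4c3C(=O)NS(=O)(=O)c3ccc([N+](=O)[O-])c(NCc4ccco4)c3)cc2)cc(C)c1Cl`: 960 nM
Compound 3 `Cc1cc(Oc2ccc(Cn3nc4ccc(Cl)cc4c3C(=O)NS(=O)(=O)c3ccc([N+](=O)[O-])c(NCc4ccn(C)n4)c3)cc2)cc(C)c1Cl`: 710 nM

In an assay on isolated protein for inhibition of Apoptosis regulator Bcl-2 (Homo sapiens), read by fluorescence polarization (a higher number here means a weaker inhibitor, a lower number a stronger inhibitor), compound 3 gives 710 nM, the second highest of the three numbers; compound 2, at 960 nM, and compound 1, at 510 nM, both lie within the scatter of it. Compound 4 `Cc1cc(Oc2ccc(Cn3nc4ccc(Cl)cc4c3C(=O)NS(=O)(=O)c3ccc([N+](=O)[O-])c(NCc4cccnc4)c3)cc2)cc(C)c1Cl` differs from compound 3 by pyridin-3-yl in place of 1-methyl-1H-pyrazol-3-yl on a saturated chain carbon bound to a nitrogen on an aromatic ring. Among the measured compounds shown here, the only measured step at this same place, a 1.4-fold lower number from compound 2 to compound 3 (0.13 log units; within the scatter), stayed within the scatter, so the one aryl-for-aryl exchange seen so far did little. Compound 4 is therefore expected to show no step beyond the scatter, a 1.0-fold lower number from compound 3 to compound 4 (0.01 log units; within the scatter). Compound 4 is estimated at 700 nM, with a range from 350 nM to 1400 nM.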

Compound 4, inhibition constant: 1220 nM
For compound 4 the middle estimate is 1.7-fold (0.24 log units) below the measured one; low and high end bracket the measured number.
By their numbers in this assay, from the lowest: compounds 1, 3, 2 and 4 (each within the scatter of the next, the first and the last beyond it).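

With pyridin-3-yl, a six-membered aromatic ring now stands at this position beside the two five-membered ones, and in this assay it stays within the scatter of both (a 1.7-fold higher number from compound 3 to compound 4 (0.24 log units; within the scatter); a 1.3-fold higher number from compound 2 to compound 4 (0.10 log units; within the scatter)). Among these three aryl groups, then, neither ring size nor the count of hetero atoms moves the number beyond the scatter. Nothing measured here accounts for these small steps.

Still open, from the compounds shown here alone, is whether an amine or a carboxylic acid on this saturated chain carbon, or a longer chain leading to the ring, would give a step beyond the scatter.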